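Removing the methyls from the imidazole of compound 2

This account rests on a few compounds, and the source may have more. Where it says the series, first, only, none or still open, it means among the compounds named here.

Among the compounds with values here, compound 2 `Cc1nc(C(c2ccc(-c3ccc4cccc(F)c4c3)[nH]c2=O)C(C)C)[nH]c1C` stands lowest of the two numbers so far in a binding assay on CHO cells for displacement of a labelled ligand from prostaglandin E2 receptor EP3 subtype (Homo sapiens), read by radioligand binding (on this read-out higher numbers stand for weaker inhibition and lower numbers for stronger inhibition), where compound 2 gives 7 nM. Within the data shown here, the only other point is compound 1 `CC(C)C(c1ccc(-c2ccc3cccc(F)c3c2)[nH]c1=O)N1CCN/C1=N\C#N`, which in this assay gives 23 nM; the swap of the five-membered rings on the saturated chain carbon brought a 3.3-fold lower number from compound 1 to compound 2 (0.52 log units; beyond the scatter).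

Compound 3 `CC(C)C(c1ncc[nH]1)c1ccc(-c2ccc3cccc(F)c3c2)[nH]c1=O` keeps the whole of compound 2 except for one change: 1H-imidazol-2-yl in place of 4,5-dimethyl-1H-imidazol-2-yl on a saturated chain carbon bound to an aromatic carbon and a saturated chain carbon. The ring type, its donor and its acceptor are unchanged; only the methyl groups are gone. Among the measured compounds shown here, no measured step removes substituents from this ring, so the single step that bears on the position, from compound 1 to compound 2, is a different kind of change and gives only a sense of scale: that one ring swap was modest.

Trimming a ring that already sits at the best number is expected to cost a little or stay within the scatter. The expectation for compound 3 is a 2.0-fold higher number from compound 2 to compound 3 (0.30 log units; within the scatter). Compound 3 is estimated at 14 nM in this assay, with a range from 4 nM to 45 nM.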

Compound 3, inhibition constant: 7.3 nM
Beside the measured number, compound 3's estimate is 1.9-fold (0.28 log units) above it; the range from low to high includes it.
By their numbers in this assay, from the lowest: compounds 2 and 3 (each within the scatter of the next); then compound 1.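

Removing both methyl groups from the 4,5-dimethyl-1H-imidazol-2-yl leaves the reading in this assay within the scatter (a 1.0-fold higher number from compound 2 to compound 3 (0.02 log units; within the scatter)), so at this position, on a saturated chain carbon bound to an aromatic carbon and a saturated chain carbon, the two methyl groups are not required to hold a number of this size. The step away from the five-membered non-aromatic ring of compound 1 also stays beyond the scatter without them (a 3.2-fold lower number from compound 1 to compound 3 (0.50 log units; beyond the scatter)), which shows that this modest step does not depend on the methyl groups and can be reached with the plain 1H-imidazol-2-yl. No supporting measurement is available to explain why the methyl groups make no difference here.

The compounds shown leave open how much substitution this ring tolerates, for instance a single methyl, an ethyl or phenyl group, or a carboxylic acid or aminomethyl group on the ring carbons. They also leave open whether the 1H-imidazol-2-yl itself can be replaced at this position by another five-membered ring, such as a pyrazole, a triazole or an oxazole, without moving the number in this binding assay.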